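Ethylsulfanyl in place of methoxymethyl: compound 4

The source may hold more compounds than are shown below. What is called first, only, known or untested is meant among the compounds shown, and "the series" means these compounds.

Measured so far in a functional assay on CHO cells for inhibition of metabotropic glutamate receptor 5 (Rattus norvegicus), read by FLIPR and calcium flux; on this read-out lower numbers stand for stronger inhibition and higher numbers for weaker inhibition:
compound 1, `Cc1ccc2ccc(-c3cccc(C#N)c3)cc2n1`: 7.7 nM
compound 2, `Cc1ccc2ccc(-c3cc(C#N)cc(C#N)c3)cc2n1`: 2 nM
compound 3, `COCc1cc(C#N)cc(-c2ccc3ccc(C)nc3c2)c1`: 2 nM

Compound 3 and compound 2 lie within the scatter of each other in this assay (no change at the digits printed from compound 2 to compound 3 (within the scatter)), and both lie apart from compound 1: a 3.9-fold lower number from compound 1 to compound 3 (0.59 log units; beyond the scatter), matching a 3.9-fold lower number from compound 1 to compound 2 (0.59 log units; beyond the scatter). So the two substituted analogues sit together, with compound 1 alone at the higher number.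

Compound 4, `CCSc1cc(C#N)cc(-c2ccc3ccc(C)nc3c2)c1`, differs from compound 3 in one place: ethylsulfanyl in place of methoxymethyl on an aromatic carbon. For the measured compounds named here, two measured steps bear on this position. Filling the bare position of compound 1 with methoxymethyl gave a 3.9-fold lower number from compound 1 to compound 3 (0.59 log units; beyond the scatter); exchanging cyano for methoxymethyl there gave no change at the digits printed from compound 2 to compound 3 (within the scatter). Two different groups at this place thus gave the same number, and neither a bare position nor an ethylsulfanyl group at it has been tested in a direct pair with compound 3. The expectation is therefore a step of no more than the scatter in this assay, in either direction, with the position occupied as it is in compound 2 and compound 3. The step from compound 3 to compound 4 is expected to be a 1.5-fold higher number from compound 3 to compound 4 (0.18 log units; within the scatter). Compound 4 is estimated at 3 nM in this assay, within 1.2 nM to 8 nM.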

Compound 4, half-maximal inhibitory concentration: 72 nM
Beside the measured number, compound 4's estimate is 24-fold (1.38 log units) below it; the whole stated range lies below it.
By their numbers in this assay, from the lowest: compounds 2 and 3 (each within the scatter of the next); then compound 1; then compound 4.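

In this assay, the position does not treat all its occupants alike: a 36-fold higher number from compound 3 to compound 4 (1.56 log units; beyond the scatter), and a 36-fold higher number from compound 2 to compound 4 (1.56 log units; beyond the scatter), so the match between methoxymethyl and cyano does not extend to ethylsulfanyl, even though ethylsulfanyl has the same counts of heavy atoms and hydrogen-bond acceptors as methoxymethyl. Filling the position is therefore no gain in itself: a 9.4-fold higher number from compound 1 to compound 4 (0.97 log units; beyond the scatter), which puts ethylsulfanyl on the opposite side of the bare position from methoxymethyl and cyano, and the series now runs in both directions from that hydrogen. Nothing in the available data gives a cause for these steps.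

Methoxymethyl and ethylsulfanyl differ both in the heteroatom, oxygen against sulfur, and in the atom that joins the group to the ring, carbon against sulfur, so the compounds shown cannot separate these two changes. An ethoxy group would keep oxygen with the attachment of ethylsulfanyl, and a methylsulfanylmethyl group would keep sulfur with the attachment of methoxymethyl, so this pair would show which of the two changes carries the step.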